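Ester variation on the shared core

The source may hold more compounds than are shown below. What is called first, only, known or untested is meant among the compounds shown, and "the series" means these compounds.

For the measured compounds named here, compound 3 `COC(=O)C1=C(C)NC(C)=C(C(=O)OCC(C)C)C1c1csc(-c2ccc(Cl)cc2)n1` stands at the top of the numbers so far in an assay on isolated protein for antagonist activity at Voltage-dependent L-type calcium channel subunit alpha-1C (Cavia porcellus), with a stated time of 15 min (a lower number here means a stronger inhibitor, a higher number a weaker inhibitor), with 46900 nM; compound 1 `COC(=O)C1=C(C)NC(C)=C(C(=O)OC)C1c1csc(-c2ccc(Cl)cc2)n1` gives 4430 nM and compound 2 `CCCOC(=O)C1=C(C)NC(C)=C(C(=O)OC)C1c1csc(-c2ccc(Cl)cc2)n1` gives 5920 nM. The steps of an 11-fold higher number from compound 1 to compound 3 (1.02 log units; beyond the scatter) and a 7.9-fold higher number from compound 2 to compound 3 (0.90 log units; beyond the scatter) both lie beyond the scatter, whereas a 1.3-fold higher number from compound 1 to compound 2 (0.13 log units; within the scatter) does not. Compound 4 `COC(=O)C1=C(C)NC(C)=C(C(=O)OC2CCCC2)C1c1csc(-c2ccc(Cl)cc2)n1` differs from compound 3 by cyclopentyl in place of isobutyl on an oxygen next to a carbonyl group. Going by the values given here, no measured pair exchanges one ester group of this size for another of similar size, so the bearing steps only show that enlarging the ester group has so far raised the number, and they give no direction for a like-for-like swap. The expected step is therefore a 1.2-fold lower number from compound 3 to compound 4 (0.07 log units; within the scatter), within the scatter. Compound 4 is estimated at 40000 nM, with a range from 14000 nM to 120000 nM.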

Compound 4, half-maximal inhibitory concentration: 7290 nM
Beside the measured number, compound 4's estimate is 5.5-fold (0.74 log units) above it, and the stated range ends above it.
By their numbers in this assay, from the lowest: compounds 1, 2 and 4 (each within the scatter of the next); then compound 3.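

Ester size alone does not set the number in this assay: cyclopentyl in place of isobutyl, the larger group for the smaller, gives a 6.4-fold lower number from compound 3 to compound 4 (0.81 log units; beyond the scatter), so the earlier rise with enlargement does not hold for compound 4. Cyclopentyl is not separated from propyl or methyl, with a 1.2-fold higher number from compound 2 to compound 4 (0.09 log units; within the scatter) and a 1.6-fold higher number from compound 1 to compound 4 (0.22 log units; within the scatter), leaving isobutyl as the only ester here that stands apart. No measured evidence bears on why isobutyl differs from the other esters.

Open, going by these compounds, is whether a longer chain such as hexyl, or an ester carrying an amine, stays level with cyclopentyl or rises as isobutyl does.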